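The compounds below may be only part of what the source reports. "The series", "measured", "known", "first", "only" and "open" are said of these compounds alone.

Compound 3 `Nc1cccc(-c2cn3c(-c4ccccc4)csc3n2)c1` shows the highest number of the three measured compounds in a functional assay on FM3A cells (Mus musculus) for inhibition, read by cell counting, with a stated time of 2 days (on this read-out lower numbers stand for stronger inhibition and higher numbers for weaker inhibition), where compound 3 gives 34000 nM. Its nearest neighbour is compound 2 `Nc1cccc(-c2cn3c(-c4ccc(Cl)cc4)csc3n2)c1`, which in this assay gives 11000 nM; the step of a 3.1-fold higher number from compound 2 to compound 3 (0.49 log units; beyond the scatter) is modest. For the measured compounds named here, compound 1 `C=C(Br)C(=O)Nc1cccc(-c2cn3nc(-c4ccc(F)cc4)sc3n2)c1`, the only compound carrying the (1-bromoethenyl)carbonyl group, gives 610 nM. Compound 4 `C=C(Br)C(=O)Nc1cccc(-c2cn3c(-c4ccccc4)csc3n2)c1` differs from compound 3 by (1-bromoethenyl)carbonyl in place of hydrogen on a nitrogen on an aromatic ring. Going by the values given here, no measured pair isolates this change: compound 1 and compound 2 differ both in that group and elsewhere, so their two values only hint that the group goes with a lower number. A downward step beyond the scatter is therefore expected, about an 11-fold lower number from compound 3 to compound 4 (1.05 log units; beyond the scatter). Compound 4 is estimated at 3000 nM, between 700 nM and 13000 nM.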

Compound 4, half-maximal inhibitory concentration: 1300 nM
Compound 4: middle estimate off by 2.3-fold (0.36 log units), on the high side, and the stated range covers the measured number.
By their numbers in this assay, from the lowest: compound 1; then compound 4; then compound 2; then compound 3.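

In this assay, replacing amino with ((1-bromoethenyl)carbonyl)amino gives a 26-fold lower number from compound 3 to compound 4 (1.42 log units; beyond the scatter) with nothing else in the structure altered. For the compounds shown here, compound 1 and compound 2 differ elsewhere as well, so only this pair ties the lower number directly to the change on this nitrogen. Nothing available explains why the number falls.

On these data alone, whether the bromine or the double bond matters remains open, since a plain acetyl group on the same nitrogen could separate the parts of the group from each other. As far as these compounds go, it is also open whether the step would be similar on the chloro-bearing compound 2.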